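The compounds below may be only part of what the source reports. "The series", "measured", "known", "first", "only" and "open" are said of these compounds alone.

Measured compounds:
Compound 1 `Cc1ccc(-c2ccc3c(c2)C(=O)C(=O)N3)cc1` gives 6000 nM in a functional assay on HepG2 cells (Homo sapiens) for antiproliferative activity, read by MTT assay, with a stated time of 48 h; on this read-out lower numbers stand for stronger inhibition and higher numbers for weaker inhibition.
Compound 2 `COc1ccc(CN2C(=O)C(=O)c3cc(-c4ccc(Cl)cc4)ccc32)cc1` gives 380 nM in this assay.
Compound 3 `COc1ccc(CN2C(=O)C(=O)c3cc(-c4ccc(OC(F)(F)F)cc4)ccc32)cc1` gives 410 nM in this assay.

Compound 2 has the lowest number of the three. Compound 3 lies within the scatter of it, so the two cannot be told apart, while compound 1 sits beyond the scatter with a much higher number. Compound 4 `COc1ccc(CN2C(=O)C(=O)c3cc(-c4ccncc4)ccc32)cc1` has not yet been measured. It differs from compound 2 in one place: pyridin-4-yl in place of 4-chlorophenyl on an aromatic carbon.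

Among the compounds with values here, only one measured step touches the same place in the molecule: a 1.1-fold higher number from compound 2 to compound 3 (0.03 log units; within the scatter). That step exchanges one group for another on the 4-chlorophenyl group and barely moves the number. The move to compound 4 replaces the whole 4-chlorophenyl group with pyridin-4-yl, which is a different kind of change, so that step is a loose guide at best. Within the data shown here, no measured step of the same kind exists.

Resting on compound 2 and on the small size of that one step, a modest move toward a higher number is expected for compound 4, a 2.1-fold higher number from compound 2 to compound 4 (0.32 log units; beyond the scatter), though a step within the scatter is also plausible. Compound 4 is therefore estimated at 800 nM, with a range from 250 nM to 2600 nM.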

Compound 4, half-maximal inhibitory concentration: > 10000 nM
Compound 4: only a limit was reported; the forecaster's own chance of this, stated with the estimate: 5%; middle value at least 12-fold (1.09 log units) from the limit.
By their numbers in this assay, from the lowest: compounds 2 and 3 (each within the scatter of the next); then compound 1. At a limit, above all of these: compound 4.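

Within the data shown here, this position on the shared core proves far more sensitive than the earlier compounds suggested. Exchanging a group on the 4-chlorophenyl ring gave a 1.1-fold higher number from compound 2 to compound 3 (0.03 log units; within the scatter), so those two compounds cannot be told apart, whereas replacing the whole ring with pyridin-4-yl gives an at least 26-fold higher number from compound 2 to compound 4 (1.42 log units; beyond the scatter). Among the compounds shown, this place accepts trifluoromethoxy in place of chloro on the carbon-only ring, but not the move to a ring with one hetero atom and one hydrogen-bond acceptor. In this assay, compound 4 gives > 10000 nM, which is a limit of the assay and not a number, so the full size of the step stays unknown: the limit of > 10000 nM in this assay, at which 1 of the 4 values shown sits.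

The change alters two things at once, since the chloro group leaves and a ring nitrogen enters, and these compounds cannot show which of the two accounts for the loss. A plain phenyl group, or a pyridine ring that keeps a chloro group, would separate the two, while an amine or a carboxylic acid on the phenyl ring would test how much else this place accepts.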